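Chloro for Nitro on the Sulfonyl Ring: Little Change Expected

A few compounds are considered here, and "the series" means these few. Any claim that something is new, unique, unknown or untested is made for them only; others in the source may bear on it.

Compound 1, `COc1ccc(S(=O)(=O)NCCCCCCNCc2ccc(Br)cc2)cc1`, gives 13000 nM in a functional assay on MIA PaCa-2 cells (Homo sapiens) for inhibition, read by MTT assay, with a stated time of 72 h; a higher number here means a weaker inhibitor of growth, a lower number a stronger inhibitor of growth.
Compound 2, `O=S(=O)(NCCCCCCNCc1ccc(Br)cc1)c1ccccc1F`, gives 13300 nM in this assay.
Compound 3, `O=[N+]([O-])c1ccccc1S(=O)(=O)NCCCCCCNCc1ccc(Br)cc1`, gives 11700 nM in this assay.

Compound 3 has the smallest of the three numbers, yet a 1.1-fold lower number from compound 1 to compound 3 (0.05 log units; within the scatter) and a 1.1-fold lower number from compound 2 to compound 3 (0.06 log units; within the scatter) are both within the scatter, so the three compounds cannot be told apart. Compound 4, `O=S(=O)(NCCCCCCNCc1ccc(Br)cc1)c1ccccc1Cl`, differs from compound 3 by chloro in place of nitro on an aromatic carbon. All three measured steps bear on this change, since each swapped the group on the sulfonyl sulfur: a 1.0-fold higher number from compound 1 to compound 2 (0.01 log units; within the scatter), a 1.1-fold lower number from compound 1 to compound 3 (0.05 log units; within the scatter) and a 1.1-fold lower number from compound 2 to compound 3 (0.06 log units; within the scatter), none beyond the scatter. A further exchange at the same place is therefore expected to give no step beyond the scatter in this assay. Compound 4 is expected to give 12000 nM, between 6000 nM and 25000 nM, an expected step of a 1.0-fold higher number from compound 3 to compound 4 (0.01 log units; within the scatter).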

Compound 4, concentration for 50% growth inhibition: 13700 nM
Estimate against measurement, compound 4: 1.1-fold (0.06 log units) below; measured number inside the range.
By their numbers in this assay, from the lowest: compounds 3, 1, 2 and 4 (each within the scatter of the next).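

In this assay, one chlorine atom can stand where the three heavy atoms of nitro stood without any step beyond the scatter (a 1.2-fold higher number from compound 3 to compound 4 (0.07 log units; within the scatter)). The same holds for the steps from the two other compounds (a 1.0-fold higher number from compound 2 to compound 4 (0.01 log units; within the scatter); a 1.1-fold higher number from compound 1 to compound 4 (0.02 log units; within the scatter)), so all four compounds remain indistinguishable, even with a group this much smaller than nitro. Nothing measured here explains why these exchanges leave the number unmoved.

On these data alone, it remains open whether an amine or a carboxylic acid on this ring would give a step beyond the scatter. The same question stands for a shorter or longer chain elsewhere in the shared core.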